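A few compounds are considered here, and "the series" means these few. Any claim that something is new, unique, unknown or untested is made for them only; others in the source may bear on it.

Working notes on the series in a functional assay on SW480 cells (Homo sapiens) for cytotoxicity, read by MTT assay, with a stated time of 24 h; a higher number here means a weaker inhibitor, a lower number a stronger inhibitor. Compound 1 `C=CC1=C(C(=O)NCc2ccccc2)C(c2ccc(OC)c(OC)c2)OC1` gives only a limit of the assay, > 100000 nM. Compound 3 `C=CC1=C(C(=O)NCc2ccccc2)C(c2ccc(F)cc2)OC1` likewise gives only a limit, > 100000 nM. Compound 2 `C=CC1=C(C(=O)NCc2ccccc2)C(c2ccc(OC)cc2)OC1` gives 39500 nM, the one number shown among the three. The step of an at least 2.5-fold lower number from compound 1 to compound 2 (0.40 log units; beyond the scatter) and the step of an at least 2.5-fold higher number from compound 2 to compound 3 (0.40 log units; beyond the scatter) both change the aromatic substituent and reach the limit (the limit of > 100000 nM in this assay, at which 2 of the 3 values shown sit). Compound 4 `C=CC1=C(C(=O)NCCC)C(c2ccc(OC)cc2)OC1` differs from compound 2 elsewhere: ethyl in place of phenyl on a saturated chain carbon bound to an amide-type nitrogen. For the measured compounds named here, no measured step touches the group on the amide-type nitrogen, so neither step bears on this change, and no direction can be read from them. The expectation for compound 4 is therefore a step of about a 1.3-fold higher number from compound 2 to compound 4 (0.10 log units; within the scatter), which is within the scatter. Compound 4 is estimated at 50000 nM, between 15000 nM and 150000 nM.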

Compound 4, half-maximal inhibitory concentration: > 100000 nM
Compound 4: no number, only a limit; the forecaster's own chance of this, stated with the estimate: 40%; middle value at least 2.0-fold (0.30 log units) away from the limit.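

Ethyl in place of phenyl on a saturated chain carbon bound to an amide-type nitrogen gives an at least 2.5-fold higher number from compound 2 to compound 4 (0.40 log units; beyond the scatter), the only step shown at this position, so this change weakens compound 2 in this assay. Compound 4 gives only a limit, > 100000 nM. The change at the amide-type nitrogen ends at the same ceiling as the two aromatic changes, leaving compound 2 as the only compound with a number: the limit of > 100000 nM in this assay, at which 3 of the 4 values shown sit.

The full size of the step cannot be read. From the compounds shown here alone, whether a longer chain, a cyclohexyl group or an amine at this position would give a number stays open.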